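The source may hold more compounds than are shown below. What is called first, only, known or untested is meant among the compounds shown, and "the series" means these compounds.

Working notes on the series. Of the compounds shown here, three have been measured in a functional assay (aorta) with Oryctolagus cuniculus as the target; a lower number here means tighter binding, a higher number weaker binding: compound 1 `COc1cc(C(C)=O)ccc1OCCCN1CCC(C(c2ccc(F)cc2)c2ccc(F)c(F)c2)CC1` gives 1.26 nM, compound 2 `COc1cc(C(C)=O)ccc1OCCCN1CCC(C(c2ccc(F)c(F)c2)c2ccc(F)c(F)c2)CC1` gives 2.51 nM and compound 3 `COc1ccc(C(c2ccc(OC)cc2)C2CCN(CCCOc3ccc(C(C)=O)cc3OC)CC2)cc1` gives 10 nM. Compound 2 therefore lies within the scatter of compound 1, while its number is clearly lower than that of compound 3.

The next comparison is compound 4 `COc1cc(C(C)=O)ccc1OCCCN1CCC(C(O)(c2ccc(F)c(F)c2)c2ccc(F)c(F)c2)CC1`, which differs from compound 2 as follows: hydroxy in place of hydrogen on a saturated chain carbon bound to two aromatic carbons and a saturated ring carbon. This is hydroxy in place of hydrogen on a saturated chain carbon bound to two aromatic carbons and a saturated ring carbon.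

For the measured compounds named here, only one measured step isolates a single change, a 2.0-fold higher number from compound 1 to compound 2 (0.30 log units; within the scatter), and it lies within the scatter. That step concerns fluoro in place of hydrogen on an aromatic carbon, so it bears only indirectly on the new change. Going by the values given here, no measured step shows the effect of hydroxy at this place, and the direction therefore remains open. The working expectation in this assay is no shift beyond the scatter, with a wide range to reflect the missing precedent. The estimated change is a 1.2-fold higher number from compound 2 to compound 4 (0.08 log units; within the scatter). For compound 4 the expected value is 3 nM, with an estimated range of 0.8 nM to 12 nM.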

Compound 4, dissociation constant: 2.51 nM
For compound 4 the middle estimate is 1.2-fold (0.08 log units) above the measured one, and the stated range covers the measured number.
By their numbers in this assay, from the lowest: compounds 1, 2 and 4 (each within the scatter of the next); then compound 3.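

In this assay, hydroxy in place of hydrogen on a saturated chain carbon bound to two aromatic carbons and a saturated ring carbon gives no change at the digits printed from compound 2 to compound 4 (within the scatter). For the compounds shown here, this is the first measured step at this carbon, since the earlier step concerned fluoro on an aromatic carbon, and it shows that, with the two aromatic groups of compound 2 in place, this carbon can carry a hydroxy, with its hydrogen-bond donor and acceptor, without a shift beyond the scatter. No supporting measurement is available to account for this result at the position.

From the compounds shown here alone, whether the same holds with the different aromatic groups of compound 1 or compound 3 remains open, as a single step on one pair of aromatic groups cannot establish a wider pattern. Also open, going by these compounds, is how this assay responds when the hydrogen on this carbon gives way to a group other than hydroxy, such as an amine or a carboxylic acid, and whether such a group would move the number beyond the scatter in either direction.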